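The compounds below may be only part of what the source reports. "The series", "measured", "known", "first", "only" and "open" are said of these compounds alone.

Of the compounds shown here, two sharing one core have been measured so far. Compound 1 `Nc1nccc(-c2cc(OCc3ccccc3)c3c(N)n[nH]c3c2)n1` and compound 2 `Nc1cc(-c2ccc3c(N)n[nH]c3c2)ncn1` were both examined in a physicochemical assay for solubility, read by LC-MS, in phosphate buffer, measured as kinetic solubility, with a stated time of 24 h, at 25 degrees C, at pH 7.4; a lower number here means a less soluble compound, a higher number a more soluble compound. In this assay compound 1 gives 85000 nM, the highest of the two numbers, while compound 2 gives 5000 nM, a gap that lies beyond the usual scatter; as the two differ in more than one place, only their two values can be set side by side. Compound 3 `Nc1nccc(-c2cc(OC3CCCOC3)c3c(N)n[nH]c3c2)n1` has not yet been measured in this assay. It differs from compound 1 in a single place: oxan-3-yl in place of benzyl on an oxygen on an aromatic ring. Going by the values given here, no step between measured compounds that differ in one place is available to calibrate this change. The step from compound 1 to compound 3 is expected to be a modest rise, about a 1.9-fold higher number from compound 1 to compound 3 (0.27 log units; within the scatter). Compound 3 is accordingly estimated at 160000 nM in this assay, with a likely range from 60000 nM to 400000 nM.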

Compound 3, solubility: 1000000 nM
Estimate against measurement, compound 3: 6.3-fold (0.80 log units) below; measured number above the stated range.
By their numbers in this assay, from the lowest: compound 2; then compound 1; then compound 3.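

Measured in this assay, the place on an oxygen on an aromatic ring now has its first readable single change, and oxan-3-yl in place of benzyl gives a 12-fold higher number from compound 1 to compound 3 (1.07 log units; beyond the scatter) in a large step. The exchange replaces a six-membered aromatic ring of carbon only, with 0 hydrogen-bond acceptors, by a six-membered non-aromatic ring with 1 hetero atom and 1 hydrogen-bond acceptor, so the number at this place clearly responds to the group it carries. No measurement of any property of the two groups bears on the step, and it stands without an explanation.

Compound 1 and compound 3 alone do not separate the loss of the aromatic ring from the entry of the ring oxygen. On these data alone, a cyclohexyl group, which has the non-aromatic ring without the oxygen, or a piperidine ring, which carries an amine, on the same oxygen remains open.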